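The source may report more compounds than this note shows. Statements on the series, on what has been measured and on what is new or still open speak of the compounds shown alone.

In a functional assay on A549 cells (Homo sapiens) for inhibition, read by MTT assay, with a stated time of 72 h (on this read-out higher numbers stand for weaker inhibition and lower numbers for stronger inhibition), three close relatives sharing one core have been measured. Compound 1 (`CC1=NN(c2ccccc2)C(=O)[C@]12C(=O)C=CC[C@@H]2c1cccc(C)c1`) gives 4770 nM, compound 2 (`CC1=NN(c2ccccc2)C(=O)[C@]12C(=O)C=CC[C@H]2c1ccccc1`) gives 8290 nM, and compound 3 (`CC1=NN(c2ccccc2)C(=O)[C@@]12C(=O)C=CC[C@H]2c1ccccc1`) gives 3770 nM. Compound 3 thus lies within the usual scatter of compound 1 and clearly below compound 2.

The next compound to test is compound 4 (`CC1=NN(c2ccccc2)C(=O)[C@]12C(=O)C=CC[C@@H]2c1ccccc1`). Set against compound 3, nothing leaves and nothing enters: the two compounds have the same atoms and bonds and differ only in configuration as drawn: 2 of 2 stereo elements differ (all stereocentres are inverted: mirror images); a stereocentre at a saturated ring carbon is drawn R in compound 3 and S in compound 4; a stereocentre at a saturated ring carbon is drawn S in compound 3 and R in compound 4. The two are mirror images.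

Among the measured compounds shown here, only one measured step bears on this change: a 2.2-fold lower number from compound 2 to compound 3 (0.34 log units; beyond the scatter). It is modest, yet it shows that configuration alone can move the number, due to the fact that compounds 2 and 3 differ only in the configuration as drawn. Compound 4 inverts both stereocentres of compound 3 rather than one, and the direction of the effect cannot be read with certainty from a single step. A small rise of no more than similar size is therefore expected. The expected change is a 1.5-fold higher number from compound 3 to compound 4 (0.16 log units; within the scatter). Compound 4 is estimated at 5500 nM, with an expected range of 2800 nM to 10500 nM.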

Compound 4, half-maximal inhibitory concentration: 9180 nM
Compound 4: middle estimate off by 1.7-fold (0.22 log units), on the low side, and the stated range covers the measured number.
By their numbers in this assay, from the lowest: compounds 3, 1, 2 and 4 (each within the scatter of the next, the first and the last beyond it).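

Mirror images need not behave alike here, since the step of a 2.4-fold higher number from compound 3 to compound 4 (0.39 log units; beyond the scatter) lies beyond the scatter, and this gap can come only from the arrangement in space: the fact that compounds 3 and 4 differ only in the configuration as drawn.

The two stereocentres also no longer look equal, as inverting one of them gives a 2.2-fold lower number from compound 2 to compound 3 (0.34 log units; beyond the scatter) beyond the scatter, while inverting the other gives a 1.1-fold higher number from compound 2 to compound 4 (0.04 log units; within the scatter) within it, though these two steps alone cannot show that this holds for other members of the series.

The step of a 1.9-fold higher number from compound 1 to compound 4 (0.28 log units; within the scatter) stays within the scatter, so hydrogen in place of methyl on an aromatic carbon has no readable effect in this configuration.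

Open, going by these compounds, is whether the mirror image of compound 1 would sit as far from compound 1 as compound 3 does from compound 4. Also open, on these data alone, is whether a larger change at that aromatic carbon, such as an amine or a carboxylic acid, would move the number.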